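The source may report more compounds than this note shows. Statements on the series, on what has been measured and on what is new or still open speak of the compounds shown alone.

Measured compounds in a functional assay on cells (Cancer cell lines, Homo sapiens) for cytotoxicity, with a stated time of 48 h; on this read-out higher numbers stand for weaker inhibition of growth and lower numbers for stronger inhibition of growth:
compound 1 `COc1cc2c(/C=C3/C(=O)Nc4ccc(Cl)cc43)c(Cl)n(Cc3cc(OC)c(OC)c(OC)c3)c2cc1C`, giving 5500 nM;
compound 2 `COc1ccc2c(c1)/C(=C\c1c(Cl)n(Cc3cc(OC)c(OC)c(OC)c3)c3cc(C)c(OC)cc13)C(=O)N2`, giving 57500 nM;
compound 3 `COc1c(/C=C2/C(=O)Nc3ccc(Cl)cc32)c2ccccc2n1-c1ccccc1`, giving 13800 nM.

Compound 2 differs from compound 1 by methoxy in place of chloro on an aromatic carbon, and this change weakened the compound markedly: a 10-fold higher number from compound 1 to compound 2 (1.02 log units; beyond the scatter). Compound 4 `COc1ccc2c(c1)/C(=C\c1c(OC)n(-c3ccccc3)c3ccccc13)C(=O)N2` stands to compound 3 as compound 2 stands to compound 1, through (methoxy in place of chloro on an aromatic carbon), the same change at the same place. The difference between the core of compound 1 and the core of compound 3 is not broken down here, so whether that difference alters the outcome of the change cannot be judged from what is shown. Resting on the single earlier step of a 10-fold higher number from compound 1 to compound 2 (1.02 log units; beyond the scatter), compound 4 is expected to show a loss of similar size: a 7.2-fold higher number from compound 3 to compound 4 (0.86 log units; beyond the scatter). Compound 4 is therefore estimated at 100000 nM, with a likely range from 30000 nM to 300000 nM.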

Compound 4, concentration for total growth inhibition: 7240 nM
The estimate for compound 4 lay 14-fold (1.14 log units) above the measured number; measured number outside the range, below it.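

In this assay the swap of chloro for methoxy on an aromatic carbon gave a 1.9-fold lower number from compound 3 to compound 4 (0.28 log units; within the scatter), so the clear loss seen on the core of compound 1 did not carry over to the core of compound 3. The same change therefore behaved differently on the two cores: the same change on two cores in this assay, a 10-fold higher number (1.02 log units; beyond the scatter) from compound 1 to compound 2 and a 1.9-fold lower number (0.28 log units; within the scatter) from compound 3 to compound 4, 20-fold (1.30 log units) apart, beyond the scatter of two such steps. This shows that the result of this change on one core in this series cannot simply be assumed on another, but it does not show which part of the difference between the cores matters, and two pairs give no general rule.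

The compounds shown leave open how an amine or a longer chain such as ethoxy would behave on this aromatic carbon on either core.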